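The source may hold more compounds than are shown below. What is called first, only, known or untested is meant among the compounds shown, and "the series" means these compounds.

Measured so far:
- compound 1 `CCOC(=O)c1cnn(-c2nc(-c3ccc(OC)cc3)c(C#N)c(=O)n2C)c1N`: 74 ug/mL
- compound 2 `CSc1nc(-c2ccco2)c(C#N)c(=O)n1C`: 79 ug/mL

In a functional assay, with a stated time of 10 min (on this read-out lower numbers stand for stronger inhibition and higher numbers for weaker inhibition), compound 1 gives 74 ug/mL, the lowest of the two numbers. Compound 2 gives 79 ug/mL, which sits within the scatter of compound 1, so the two cannot be separated. Compound 3 `CCOC(=O)c1cnn(-c2nc(-c3cccs3)c(C#N)c(=O)n2C)c1N` remains to be measured; it differs from compound 1 by thiophen-2-yl in place of 4-methoxyphenyl on an aromatic carbon. Within the data shown here, no pair of measured compounds differs in one place, so no measured step guides this change. The step from compound 1 to compound 3 is expected to be small, none beyond the scatter, as a 1.1-fold higher number from compound 1 to compound 3 (0.03 log units; within the scatter). Compound 3 is estimated at 80 ug/mL, range 40 ug/mL to 160 ug/mL.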

Compound 3, half-maximal inhibitory concentration: 109 ug/mL
For compound 3 the middle estimate is 1.4-fold (0.13 log units) below the measured one; measured number inside the range.
By their numbers in this assay, from the lowest: compounds 1, 2 and 3 (each within the scatter of the next).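

In this assay, among these compounds, thiophen-2-yl in place of 4-methoxyphenyl on the aromatic carbon ortho to a cyano group gives a 1.5-fold higher number from compound 1 to compound 3 (0.17 log units; within the scatter) and is the only single-place step available. This carbon therefore accepts a five-membered aromatic ring with sulfur in place of the six-membered carbon ring without a change that can be resolved from the scatter. No measurement at hand bears on the reason for this result. On these data alone, whether an amine or a longer alkyl chain on this carbon would move the number beyond the scatter remains open.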